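This account rests on a few compounds, and the source may have more. Where it says the series, first, only, none or still open, it means among the compounds named here.

This set concerns an ADME assay on HEL cells (Homo sapiens) for cytotoxicity; a higher number here means that more compound is tolerated, a lower number that less compound is tolerated. Compound 1 `Cc1ccccc1OCCCCCn1ccc(=O)[nH]c1=O` is the only one with a result: in this assay compound 1 reaches > 100000 nM, which is a limit of the assay and not a number. Compound 2 `O=c1ccn(CCCCCOc2ccc(Cl)cc2)c(=O)[nH]1` has no result in this assay, recorded as "not determined" (no result reported). Compound 3 `O=c1ccn(CCCCCCOc2ccc(Br)cc2)c(=O)[nH]1` likewise has none in this assay, recorded as "not determined" (no result reported). So compound 2 stands without a number of its own, beside one limit and one empty entry. Compound 4 `CC(C)c1ccc(OCCCCCn2ccc(=O)[nH]c2=O)cc1` differs from compound 2 by isopropyl in place of chloro on an aromatic carbon. No step between measured compounds is shown. In this assay the step is expected to stay within the scatter, with no clear direction. Compound 1 sits at the limit of > 100000 nM in this assay, at which 1 of the 3 values shown sits, so the result may again end in a limit. Compound 4 is expected to give 100000 nM, between 30000 nM and 300000 nM.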

Compound 4, half-maximal cytotoxic concentration: > 100000 nM
Compound 4 gave a limit, no number (the forecaster's own chance of this, stated with the estimate: 70%); the middle value sits exactly at the limit.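

No new step can be read, since compound 2 has no result to set against compound 4, whose value is a limit and not a number. The compounds shown leave open whether exchanging chloro for isopropyl changes the outcome in this assay at all.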